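The source may hold more compounds than are shown below. What is called first, only, known or untested is meant among the compounds shown, and "the series" means these compounds.

Measured compounds:
- compound 1, `COC(=O)c1nc(C)n(-c2ccc(F)cc2)n1`, 8700 nM
- compound 2, `CCc1nc(C(=O)OC)nn1-c1ccc(F)cc1`, 11000 nM
- compound 3, `COC(=O)c1nc(-c2ccc[nH]2)n(-c2ccc(F)cc2)n1`, 9010 nM

All three values come from a functional assay on Jurkat cells (Homo sapiens) for inhibition, read by MTT assay, with a stated time of 72 h; on this read-out lower numbers stand for stronger inhibition of growth and higher numbers for weaker inhibition of growth. Within the data shown here, compound 3 sits second highest of the three numbers, but its neighbours are close: the step of a 1.0-fold higher number from compound 1 to compound 3 (0.02 log units; within the scatter) and the step of a 1.2-fold lower number from compound 2 to compound 3 (0.09 log units; within the scatter) are both within the scatter, so no compound can be called stronger or weaker than another.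

Compound 4, `CCOC(=O)c1nc(-c2ccc[nH]2)n(-c2ccc(F)cc2)n1`, is not yet measured. It differs from compound 3 by methyl in place of hydrogen on a saturated chain carbon bound to an oxygen next to a carbonyl group. Among the measured compounds shown here, only one measured step is of a similar kind, a methyl in place of hydrogen on a saturated chain carbon, though there bound to an aromatic carbon: a 1.3-fold higher number from compound 1 to compound 2 (0.10 log units; within the scatter), within the scatter. For the measured compounds named here, nothing among the measured compounds shows a change at the ester chain itself.

On this basis the step of a 1.0-fold lower number from compound 3 to compound 4 (0.00 log units; within the scatter) is expected to be small, with no direction beyond the scatter. For compound 4 in this assay the estimate is 9000 nM, with a range from 4000 nM to 20000 nM.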

Compound 4, concentration for 50% growth inhibition: > 100000 nM
Compound 4: a limit, no number (the forecaster's own chance of this, stated with the estimate: 5%); middle value at least 11-fold (1.04 log units) from the limit.
By their numbers in this assay, from the lowest: compounds 1, 3 and 2 (each within the scatter of the next). At a limit, above all of these: compound 4.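

The ester chain turns out to be a sensitive place in this assay: the step of an at least 11-fold higher number from compound 3 to compound 4 (1.04 log units; beyond the scatter) shows that going from methoxycarbonyl to ethoxycarbonyl is no minor edit on this core. Compound 4 gives > 100000 nM, which is a limit of the assay and not a number. An added methyl therefore has no fixed effect across these compounds, and the outcome depends on where it is placed: the same change on two cores in this assay, a 1.3-fold higher number (0.10 log units; within the scatter) from compound 1 to compound 2 and an at least 11-fold higher number (1.04 log units; beyond the scatter) from compound 3 to compound 4, at least 8.7-fold (0.94 log units) apart, beyond the scatter of two such steps

Going by these compounds, whether this weaker growth inhibition belongs to the ethyl ester alone or extends to other changes at this place remains open, and a propyl ester, a carboxylic acid or an amide there would help to tell. On these data alone, it also remains open whether an ethyl ester on the core of compound 1 or compound 2 would show a step of similar size.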